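Ethoxymethyl to methoxymethyl on the saturated chain: bioavailability outlook

The source may hold more compounds than are shown below. What is called first, only, known or untested is meant among the compounds shown, and "the series" means these compounds.

Compound 1 `CCOC[C@H]1C[C@@](CC(C)C)(C(=O)O)N(C(=O)c2ccc(C(C)(C)C)c(OC)c2)[C@H]1c1nccs1` has the highest value of the three measured compounds in an in vivo ADME assay on the whole organism (strain Sprague-Dawley) for pharmacokinetics, with Rattus norvegicus as the target (a lower number here means that a smaller share of the oral dose reaches the circulation, a higher number that a larger share of the oral dose reaches the circulation), where compound 1 gives 120%. Compound 3 `COC[C@@H]1C[C@@](CC(C)C)(C(=O)O)N(C(=O)c2ccc(C(C)(C)C)c(OC)c2)[C@H]1c1nccs1` gives 44% in this assay, and compound 2 `CC(C)C[C@@]1(C(=O)O)C[C@H](C(N)=O)[C@H](c2nccs2)N1C(=O)c1ccc(C(C)(C)C)c(Br)c1` gives 2%, both well beyond the scatter below compound 1. Compound 4 `COC[C@H]1C[C@@](CC(C)C)(C(=O)O)N(C(=O)c2ccc(C(C)(C)C)c(OC)c2)[C@H]1c1nccs1` is not yet measured in this assay. It differs from compound 1 as follows: hydrogen in place of methyl on a saturated chain carbon bound to an oxygen on a saturated carbon. For the measured compounds named here, no measured pair isolates this change, so the direction rests on expectation alone. A modest fall in oral exposure is expected, possibly no more than the scatter. The step from compound 1 to compound 4 is estimated as a number 35 percentage points lower from compound 1 to compound 4 (beyond the scatter). Compound 4 is expected to give 85% in this assay, within 45% to 120%.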

Compound 4, oral bioavailability in the Rattus norvegicus assay: 59%
Estimate against measurement, compound 4: 26 percentage points above; measured number inside the range.
By their numbers in the Rattus norvegicus assay, from the lowest: compound 2; then compound 3; then compound 4; then compound 1.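

In the Rattus norvegicus assay, ethoxymethyl to methoxymethyl is a large step at this position: a number 61 percentage points lower from compound 1 to compound 4 (beyond the scatter). In the Rattus norvegicus assay, configuration at the saturated ring carbon also matters, though less: a number 15 percentage points higher from compound 3 to compound 4 (beyond the scatter). In a physicochemical assay for lipophilicity (on this read-out lower numbers stand for lower lipophilicity and higher numbers for higher lipophilicity), compound 1 gives 2.7 and compound 4 gives 2.2, a gap beyond the scatter, so the shorter chain lowers both read-outs in this one pair.

A single pair cannot show whether the two falls are linked. Going by these compounds, how a propoxymethyl or hydroxymethyl group at this position would read remains open, as does the ethoxymethyl chain with the configuration of compound 3.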